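Triazole in place of carboxyphenyl on the biaryl amide

A few compounds are considered here, and "the series" means these few. Any claim that something is new, unique, unknown or untested is made for them only; others in the source may bear on it.

Compound 1 `O=C(NCCCCCCCn1cc(-c2ccc[n+]([O-])c2)nn1)c1ccccc1-c1ccccc1` and compound 2 `O=C(O)c1cccc(-c2ccccc2C(=O)NCCCCCCCn2cc(-c3cccnc3)nn2)c1` have been tested in an assay for inhibition of Nicotinamide phosphoribosyltransferase (Mus musculus), read by fluorescence, with a stated time of 1 h, in the presence of a further agent that is not named here; on this read-out lower numbers stand for stronger inhibition and higher numbers for weaker inhibition. Compound 1 returns only a limit of the assay in this assay, > 500 nM. Compound 2 likewise returns only a limit in this assay, > 500 nM. Where compound 2 stands is therefore known only as a limit; both values sit at the same edge of the measured range, (the limit of > 500 nM in this assay, at which 2 of the 2 values shown sit), and no number separates them. Among the compounds with values here, no step between two measured compounds is available in this set.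

Compound 3 `O=C(NCCCCCCCn1cc(-c2cccnc2)nn1)c1ccccc1-n1ccnn1` is not yet measured. It differs from compound 2 by 1H-1,2,3-triazol-1-yl in place of 3-carboxyphenyl on an aromatic carbon. From the compounds shown here alone, because compound 2 shows only a limit, > 500 nM, the size and direction of the step to compound 3 cannot be read from any measured pair; no move beyond the usual scatter is expected, and the direction stays open. The estimate for compound 3 in this assay is 700 nM, with a range from 150 nM to 3000 nM, which corresponds to an expected step that the limit leaves unreadable from compound 2 to compound 3. It is expected that compound 3 may again return only a limit.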

Compound 3, half-maximal inhibitory concentration: 3.4 nM
Compound 3: the middle estimate sits 210-fold (2.31 log units) above what was measured; measured number outside the range, below it.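

In this assay, within the data shown here, the change at this aromatic carbon, ortho to a large group, is the first to move the read-out: 1H-1,2,3-triazol-1-yl in place of 3-carboxyphenyl gives an at least 140-fold lower number from compound 2 to compound 3 (2.16 log units; beyond the scatter). Compound 2 carries only a limit, > 500 nM, so the size of this step is a bound and not an exact figure. Compound 3 is also the only compound here with a measured number, and the other values sit at the edge of the range: the limit of > 500 nM in this assay, at which 2 of the 3 values shown sit.

The pair does not separate the loss of the carboxylic acid from the exchange of a six-membered carbon ring for a five-membered ring with 3 hetero atoms, since both occur in the same step. A 1H-pyrazol-1-yl group at the same place would test whether the result depends on the particular ring nitrogens of the 1H-1,2,3-triazol-1-yl group, and a phenyl group at this place on the compound 3 scaffold would show how much of the step belongs to the carboxylic acid alone.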